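Removing the Acetyl Group From Compound 2

The source may report more compounds than this note shows. Statements on the series, on what has been measured and on what is new or still open speak of the compounds shown alone.

Compound 1 `CC(=O)OC(C)n1cnc2c(S)nc(N)nc21`: 89000 nM
Compound 2 `CC(=O)OC(C)n1cnc2c(S)nc(F)nc21`: > 500000 nM

In a functional assay on HeLa cells (Homo sapiens) for inhibition (on this read-out lower numbers stand for stronger inhibition and higher numbers for weaker inhibition), compound 1 gives 89000 nM. Compound 2 reaches only the assay limit, > 500000 nM, which is the limit of > 500000 nM in this assay, at which 1 of the 2 values shown sits. Among the measured compounds shown here, the sole measured step, an at least 5.6-fold higher number from compound 1 to compound 2 (0.74 log units; beyond the scatter), concerns fluoro in place of amino on an aromatic carbon. Compound 3 `CC(O)n1cnc2c(S)nc(F)nc21` differs from compound 2 by hydrogen in place of acetyl on an oxygen on a saturated carbon. For the measured compounds named here, no measured step touches this place, so there is nothing to size the change by. Compound 3 is therefore expected to stay near the limit, with a number no higher from compound 2 to compound 3 (the limit leaves the size open) and an estimated 500000 nM, spanning 100000 nM to 2500000 nM.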

Compound 3, half-maximal inhibitory concentration: > 500000 nM
Compound 3: only a limit was reported (the forecaster's own chance of this, stated with the estimate: 75%); the middle value lies on the limit itself.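

Compound 2 and compound 3 both stop at a limit rather than a number, so no step can be read between them: the limit of > 500000 nM in this assay, at which 2 of the 3 values shown sit. From the compounds shown here alone, whether changing acetoxy to hydroxy alters inhibition at all remains open.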